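Two aryl-imidazole amines at the cytotoxicity ceiling, and a third

This account rests on a few compounds, and the source may have more. Where it says the series, first, only, none or still open, it means among the compounds named here.

This study looks at whether a small family of compounds harms mouse fibroblast cells, judged in a toxicity assay on NIH3T3 cells (Mus musculus) for cytotoxicity, read by resazurin assay; on this read-out higher numbers stand for an effect only at larger amounts of compound and lower numbers for an effect already at smaller amounts. Compound 1, `COC(=O)c1ccc(NCc2cncn2Cc2cccc(F)c2)cc1-c1ccccc1`, has a methoxycarbonyl group on its aniline ring. In this assay compound 1 gives only a limit of the assay, > 1000 nM, not a measured number. Compound 2, `c1ccc(-c2ccc(Cn3cncc3CNc3ccc(N4CCCCC4)c(-c4ccccc4)c3)cc2)cc1`, carries a piperidin-1-yl group on the same ring instead, together with a larger phenyl-bearing arm on the imidazole. In this assay compound 2 likewise reaches only a limit of the assay, > 1000 nM. Compound 2 therefore stands at the top of what the assay can report, and so does every other value here: the limit of > 1000 nM in this assay, at which 2 of the 2 values shown sit.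

Compound 3, `CCOC(=O)c1ccc(NCc2cncn2Cc2ccc(-c3ccccc3)cc2)cc1-c1ccccc1`, is still to be tested. It differs from compound 2 by the change (ethoxycarbonyl in place of piperidin-1-yl on an aromatic carbon), an ethoxycarbonyl in place of piperidin-1-yl on an aromatic carbon of a six-membered aromatic ring of carbon only, ortho to a phenyl group. No measured step is shown for this change. The step is expected to be none beyond the usual scatter, a step that the limit leaves unreadable from compound 2 to compound 3, because of the limit of > 1000 nM in this assay, at which 2 of the 2 values shown sit. Compound 3 is estimated at 3000 nM, within 1000 nM to 10000 nM, most likely again reported only as a limit.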

Compound 3, half-maximal effective concentration: > 10000 nM
Compound 3: no number, only a limit; the forecaster's own chance of this, stated with the estimate: 80%; at least 3.3-fold (0.52 log units) between middle value and limit.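

Compound 3 gives only a limit of the assay, > 10000 nM. Among the compounds shown here, compound 2 also gives only a limit, so no step from compound 2 to compound 3 can be read in this assay. The compounds shown leave open at what amount any of them would show an effect, and whether ethoxycarbonyl in place of piperidin-1-yl changes that amount.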